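This account rests on a few compounds, and the source may have more. Where it says the series, first, only, none or still open, it means among the compounds named here.

Compound 2 `CCC(=O)N1CC[C@H](Oc2ncnc3c2nc(-c2cnc(C)nc2)n3CC)C1` gives 3.9 h in an ADME assay (Canis lupus familiaris, strain Beagle) for metabolic stability; on this read-out lower numbers stand for a shorter-lived compound and higher numbers for a longer-lived compound. Compound 1 `CCn1c(-c2cnc(C)nc2)nc2c(O[C@H]3CCN(C(=O)C4CC4)C3)ncnc21` keeps the same core and differs only by cyclopropyl in place of ethyl on a carbonyl carbon; in this assay compound 1 gives 1.3 h, so that the step of a 3.0-fold lower number from compound 2 to compound 1 (0.48 log units; beyond the scatter). Compound 3 `CCC(=O)N1CC[C@H](Nc2ncnc3c2nc(-c2cnc(C)nc2)n3CC)C1` has a core that differs from that of compound 2, and the difference between the two cores is not broken down here; in this assay compound 3 gives 2.7 h, a number within the scatter of that of compound 2 and beyond the scatter of that of compound 1. Compound 4 `CCn1c(-c2cnc(C)nc2)nc2c(N[C@H]3CCN(C(=O)C4CC4)C3)ncnc21` stands to compound 3 as compound 1 stands to compound 2: it differs by cyclopropyl in place of ethyl on a carbonyl carbon, the same change at the same place, a change that occurs twice among these compounds. Resting on the step of a 3.0-fold lower number from compound 2 to compound 1 (0.48 log units; beyond the scatter), compound 4 is expected to show a step of about the same size, a 2.7-fold lower number from compound 3 to compound 4 (0.43 log units; beyond the scatter). Because compound 3 sits at 2.7 h, compound 4 is estimated at 1 h, with a likely range from 0.5 h to 2 h.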

Compound 4, half-life: 4.7 h
Estimate against measurement, compound 4: 4.7-fold (0.67 log units) below; the measured number lies above the stated range.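

Cyclopropyl in place of ethyl on a carbonyl carbon gives a 1.7-fold higher number from compound 3 to compound 4 (0.24 log units; within the scatter) in this assay, so the change does not carry a single effect from one core to the other in this series: the same change on two cores in this assay, a 3.0-fold lower number (0.48 log units; beyond the scatter) from compound 2 to compound 1 and a 1.7-fold higher number (0.24 log units; within the scatter) from compound 3 to compound 4, 5.2-fold (0.72 log units) apart, beyond the scatter of two such steps. The shorter half-life seen with the first pair therefore cannot be read as an effect of the cyclopropyl group alone, and the outcome of this change here depends on the core that carries it. Among these compounds, with only two pairs, this does not show which feature separating the two cores is responsible, nor how the change would behave on any further core.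

As far as these compounds go, only ethyl and cyclopropyl appear on that carbonyl carbon, so it remains open how a cyclobutyl group or a longer chain there would behave on either core. From the compounds shown here alone, it is also open whether a third core, with a different atom in place of the linking oxygen or nitrogen, would follow the step to compound 1 or the step to compound 4.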